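Thiazolyl for fluorophenyl on the cyclopropane of compound 3

The source may hold more compounds than are shown below. What is called first, only, known or untested is meant among the compounds shown, and "the series" means these compounds.

Three compounds of the series carry a measured number. Compound 1 `CC(C)C[C@H](N)CCN(C(=O)[C@@H]1C[C@H]1c1ccccc1)c1ccc(-c2ccccc2)cc1` gives 3 nM in a functional assay for agonist activity at G protein-coupled receptor 88 (Homo sapiens), read by HTRF and cAMP accumulation; on this read-out higher numbers stand for an effect only at larger amounts of compound and lower numbers for an effect already at smaller amounts. Among the measured compounds shown here, compound 2 `CCC(C)CNCCN(C(=O)[C@@H]1C[C@H]1c1ccccc1)c1ccc(-c2ccccc2)cc1` gives 4.7 nM in this assay; the one measured step, a 1.6-fold higher number from compound 1 to compound 2 (0.19 log units; within the scatter), concerns the amine-bearing chain only. Compound 3 `CC[C@H](C)[C@H](N)CN(C(=O)[C@@H]1C[C@H]1c1cccc(F)c1)c1ccc(-c2ccccc2)cc1` gives 560 nM in this assay, the highest of the three numbers, and its gaps to compound 1 and to compound 2 both lie beyond the scatter.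

Compound 4 `CC[C@H](C)[C@H](N)CN(C(=O)[C@@H]1C[C@H]1c1nc(C)c(C)s1)c1ccc(-c2ccccc2)cc1` is not yet measured. It differs from compound 3 in one place: 4,5-dimethyl-1,3-thiazol-2-yl in place of 3-fluorophenyl on a saturated ring carbon. For the measured compounds named here, no measured step touches the group on the three-membered ring; the only step available, from compound 1 to compound 2, sits on the chain and says nothing about the aryl-to-heteroaryl exchange. The expectation for compound 4 therefore rests on compound 3 alone, with a wide range on either side and no direction preferred beyond the scatter.

In this assay compound 4 is expected at 600 nM, with a range from 150 nM to 2500 nM. The expected step is then a 1.1-fold higher number from compound 3 to compound 4 (0.03 log units; within the scatter), which is counted as no step beyond the scatter.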

Compound 4, half-maximal effective concentration: 3600 nM
Estimate against measurement, compound 4: 6.0-fold (0.78 log units) below; measured number outside the range, above it.
By their numbers in this assay, from the lowest: compounds 1 and 2 (each within the scatter of the next); then compound 3; then compound 4.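

In this assay, among the compounds shown here, the group on the saturated ring carbon of the three-membered ring does register: 4,5-dimethyl-1,3-thiazol-2-yl in place of 3-fluorophenyl gives a 6.4-fold higher number from compound 3 to compound 4 (0.81 log units; beyond the scatter), the first measured step at this position and one beyond the scatter. The two groups share the same heavy-atom count, so the step goes with a change of ring and hetero atoms and not with a change in that count, although a single pair cannot show which feature of the exchange matters. No measurement at hand bears on why the number moves.

The compounds shown do not separate the contribution of the thiazole ring from that of its two methyl groups; an unsubstituted 1,3-thiazol-2-yl or a pyridyl ring at the same place would bear on that. They also leave open whether the same exchange gives a step of similar size on the chain of compound 1, whose number is far lower, or whether this reading holds only with the chain that compound 3 and compound 4 share.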